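Swapping a nitro for a chloro on the pyridine

This account rests on a few compounds, and the source may have more. Where it says the series, first, only, none or still open, it means among the compounds named here.

Compound 1 `O=C(CCCc1ccc(Cl)cc1)N1CCc2c(Cl)c(O)c(O)c(Cl)c2C1`, compound 2 `O=C(/C=C/c1ccccc1)N1CCc2c(Cl)c(O)c(O)c(Cl)c2C1` and compound 3 `O=C(CCCc1ccc([N+](=O)[O-])cn1)N1CCc2c(Cl)c(O)c(O)c(Cl)c2C1` share one core and differ only in the chain attached to the amide carbonyl. In a functional assay (Homo sapiens), tested at 10 uM (a higher number here means a weaker effect of the compound at the concentration tested, a lower number a stronger effect), compound 1 gives 16%, compound 2 gives 41% and compound 3 gives 33%. Compound 3 therefore stands second highest of the three numbers: compound 2 sits within the scatter of it, while compound 1 lies beyond the scatter, as a number 17 percentage points higher from compound 1 to compound 3 (beyond the scatter) shows. Going by the values given here, that one step, 4-chlorophenyl to 5-nitropyridin-2-yl, is the only measured step bearing on the next change, and it folds two alterations together: a ring switch and a nitro in place of a chloro.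

Compound 4 `O=C(CCCc1ccc(Cl)cn1)N1CCc2c(Cl)c(O)c(O)c(Cl)c2C1` undoes only the second alteration: chloro in place of nitro on an aromatic carbon. It keeps the pyridine of compound 3 yet carries the chloro of compound 1. Among the compounds with values here, no measured step separates the two alterations, so compound 4 is expected to land between compound 1 and compound 3, a modest downward step in this assay, estimated as a number 10 percentage points lower from compound 3 to compound 4 (within the scatter). For compound 4 the estimate is 23%, with a range from 10% to 38%.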

Compound 4, a percentage reported as activity, at one concentration (the size of the read-out at that concentration, not a potency): 15%
Estimate against measurement, compound 4: 8 percentage points above, and the stated range covers the measured number.
By their numbers in this assay, from the lowest: compounds 4 and 1 (each within the scatter of the next); then compounds 3 and 2 (each within the scatter of the next).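

In this assay, the change from 5-nitropyridin-2-yl to 5-chloropyridin-2-yl separates the two alterations folded together earlier: swapping nitro for chloro alone gives a clear shift towards a stronger effect (a number 18 percentage points lower from compound 3 to compound 4 (beyond the scatter)), while the ring switch alone, with the chloro kept, gives no readable change (a number 1 percentage points lower from compound 1 to compound 4 (within the scatter)). Among these compounds, then, the gap between compound 1 and compound 3 goes with the nitro and not with the ring nitrogen. Nothing measured here says why nitro and chloro differ at this place.

From the compounds shown here alone, it remains open how an amine, a methoxy group or a carboxylic acid on this same ring carbon would compare with chloro and nitro. Going by these compounds, whether a nitro would have the same effect on the phenyl ring of compound 1 also stays unknown.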